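Swapping a Bromophenyl for a Phenylethenyl Group

The source may report more compounds than this note shows. Statements on the series, on what has been measured and on what is new or still open speak of the compounds shown alone.

Of the compounds shown here, two have so far been measured in a functional assay on MCF7 cells (Homo sapiens) for cytotoxicity, read by MTT assay, with a stated time of 96 h; a higher number here means a weaker inhibitor, a lower number a stronger inhibitor. Compound 1 `COc1cc(C(=O)c2cn(-c3ccccc3C)cc2-c2ccccc2)cc(OC)c1OC` gives 2200 nM. Compound 2 `COc1cc(C(=O)c2cn(-c3ccccc3)cc2-c2ccccc2Br)cc(OC)c1OC` gives 190 nM, the lowest of the two numbers; compound 1 stands a good deal higher, and that gap lies beyond the usual scatter. For the measured compounds named here, no step between compounds that differ in a single place has been worked out, so this pair shows only that its two values differ.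

Compound 3 `COc1cc(C(=O)c2cn(-c3ccccc3)cc2/C=C/c2ccccc2)cc(OC)c1OC` has not yet been measured. It differs from compound 2 in one place: 2-phenylethenyl in place of 2-bromophenyl on an aromatic carbon The change sits on an aromatic carbon of the five-membered aromatic ring with 1 nitrogen, two ring bonds from the ring nitrogen.

Nothing measured here tells how this exchange plays out. With only the value of compound 2 to rest on, the step of a 4.2-fold higher number from compound 2 to compound 3 (0.62 log units; beyond the scatter) is expected to run toward a higher number, somewhat beyond the scatter. Compound 3 is therefore estimated at 800 nM, within a range from 150 nM to 4000 nM.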

Compound 3, half-maximal inhibitory concentration: 2200 nM
Compound 3: the middle estimate sits 2.8-fold (0.44 log units) below what was measured, within the range that was stated.
By their numbers in this assay, from the lowest: compound 2; then compounds 1 and 3 (each within the scatter of the next).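

In this assay, for the compounds shown here, the exchange of 2-bromophenyl for 2-phenylethenyl on this aromatic carbon gives the only step so far that can be read at a single place: a 12-fold higher number from compound 2 to compound 3 (1.06 log units; beyond the scatter) is a large step. It shows that the group on this carbon, two ring bonds from the ring nitrogen, matters to the number in this assay, and that within this pair the 2-phenylethenyl group goes with the higher number. No measurement at hand accounts for the size or the direction of this step.

What the compounds shown leave open is whether the step follows the loss of the bromine or the arrival of the double bond outside aromatic rings, as the two groups differ in both. A 2-phenylethyl group, with a saturated chain in place of the double bond, and a 2-aminophenyl group, with an amine where the bromine stands, would each put one of these questions to the test on this same carbon.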